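The compounds below may be only part of what the source reports. "The series", "measured", "known", "first", "only" and "open" are said of these compounds alone.

Compound 3 `Cc1nc(S(C)(=O)=O)ccc1Oc1ncnc(OC2CCN(C(=O)C(C)(F)F)CC2)c1F` gives the highest of the three numbers in a functional assay on isolated protein for inhibition of Glucose-dependent insulinotropic receptor (Homo sapiens), read by HTRF and cAMP accumulation (a lower number here means that less compound is needed, a higher number that more compound is needed for the effect), at 37 nM. Compound 1 `CCC1(OC(=O)N2CCC(Oc3ncnc(Oc4ccc(S(C)(=O)=O)nc4C)c3F)CC2)CC1` gives 22 nM in this assay, and compound 2 `Cc1nc(S(C)(=O)=O)ccc1Oc1ncnc(OC2CCN(C(=O)OC3(C(F)(F)F)CCC3)CC2)c1F` gives 14.3 nM. Compound 4 `Cc1nc(S(C)(=O)=O)ccc1Oc1ncnc(OC2CCN(C(=O)c3noc(C(C)(C)F)n3)CC2)c1F` differs from compound 3 by a group of 9 heavy atoms (5 carbon, 2 nitrogen, 1 oxygen, 1 fluorine; one five-membered aromatic ring with 3 hetero atoms) in place of a group of 4 heavy atoms (2 carbon, 2 fluorine; no ring), on a carbonyl carbon. Going by the values given here, two measured steps bear on this carbonyl position: a 1.7-fold higher number from compound 1 to compound 3 (0.23 log units; within the scatter), which stays within the scatter, and a 2.6-fold higher number from compound 2 to compound 3 (0.41 log units; beyond the scatter), which goes beyond it. Replacing the difluoroethyl group with a larger ring-bearing group is therefore expected to lower the number modestly, a step of a 2.1-fold lower number from compound 3 to compound 4 (0.31 log units; beyond the scatter) for compound 4 in this assay. Compound 4 is accordingly estimated at 18 nM, with a range from 7 nM to 50 nM.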

Compound 4, half-maximal effective concentration: 14 nM
The estimate for compound 4 lay 1.3-fold (0.11 log units) above the measured number; low and high end bracket the measured number.
By their numbers in this assay, from the lowest: compounds 4, 2, 1 and 3 (each within the scatter of the next, the first and the last beyond it).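

In this assay the carbonyl carbon carries a group with a five-membered aromatic ring with 3 hetero atoms, and a 2.6-fold lower number from compound 3 to compound 4 (0.42 log units; beyond the scatter) shows that this group can stand there with a lower number than 1,1-difluoroethyl. With a 1.0-fold lower number from compound 2 to compound 4 (0.01 log units; within the scatter) and a 1.6-fold lower number from compound 1 to compound 4 (0.20 log units; within the scatter) both within the scatter, it cannot be told apart from the two groups joined through oxygen. The compounds shown leave open whether a phenyl ring, a pyridine ring or a simple amine on the carbonyl carbon would do the same, and whether the fluorine on the new group plays any part. No measurement offered here explains these steps.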